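From a pyrrole to a methoxypyridine: what rat exposure may follow

A few compounds are considered here, and "the series" means these few. Any claim that something is new, unique, unknown or untested is made for them only; others in the source may bear on it.

Compound 1, `Cc1cn2c(-c3cn[nH]c3)cnc2c(Nc2cc(Cn3cccc3)ns2)n1`, was studied in an ADME assay on the whole organism for pharmacokinetics, with Rattus norvegicus as the target, with a stated time of 6 h, at a dose of 10 mg/kg by the oral route (a lower number here means less compound in the circulation, a higher number more compound in the circulation at the dose given), yet for compound 1 the outcome in this assay reads "not determined" (no result reported), so no number can be placed on it. Compound 2, `Cc1cn2c(-c3cn[nH]c3)cnc2c(Nc2cc(Cc3ccncc3)ns2)n1`, stands the same way: in this assay compound 2 shows "not determined" (no result reported). Among the measured compounds shown here, the only number in this set belongs to compound 3, `Cc1cn2c(-c3cn[nH]c3)cnc2c(Nc2cc(Cc3ncccc3F)ns2)n1`, which in this assay gives 569 ng.h/mL. For the measured compounds named here, because no two measured compounds differ in a single place, no step between them can be traced, and nothing can be said about how a change of this kind has moved the read-out before.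

Compound 4, `COc1cccc(Cc2cc(Nc3nc(C)cn4c(-c5cn[nH]c5)cnc34)sn2)n1`, is the next to be tested. It differs from compound 1 by the change (6-methoxypyridin-2-yl in place of 1H-pyrrol-1-yl on a saturated chain carbon bound to an aromatic carbon). Going by the values given here, without a comparable step in hand, the direction of the effect cannot be judged from the data; the only anchor is the number from compound 3, a close relative with a different pyridine ring. The expectation for compound 4 in this assay is therefore a value near that anchor, estimated at 450 ng.h/mL, with a plausible range from 120 ng.h/mL to 1700 ng.h/mL, and the true number could fall anywhere within it.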

Compound 4, area under the concentration-time curve: 2300 ng.h/mL
For compound 4 the middle estimate is 5.1-fold (0.71 log units) below the measured one; the whole stated range lies below it.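

Among the compounds shown here, this is the first step in the set that can be read, since compound 3 and compound 4 differ in one place only. In this assay the exchange of 3-fluoropyridin-2-yl for 6-methoxypyridin-2-yl gives a 4.0-fold higher number from compound 3 to compound 4 (0.61 log units; beyond the scatter) and so shows that the group on a saturated chain carbon bound to an aromatic carbon can change how much compound is found in the circulation, even with the rest of the molecule held constant. Nothing in the available data explains the rise, which stands as an observation without a known cause.

The change from 1H-pyrrol-1-yl to 6-methoxypyridin-2-yl itself cannot be read, as compound 1 has no number to compare with, and compound 2 likewise offers no comparison. As far as these compounds go, it also remains open whether the higher number goes with the methoxy group or with the pyridine ring as a whole, and whether an ethoxy group or a dimethylamino group at the same place on that pyridine ring would give a similar result.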